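The compounds below may be only part of what the source reports. "The series", "measured", "known", "first", "only" and "open" are said of these compounds alone.

Compound 3 `CC1(C)C=C(n2ccccc2=O)c2cc(C=C(C#N)C#N)ccc2O1` gives 6.95 in a functional assay (aorta) with Rattus norvegicus as the target (on this read-out higher numbers stand for higher potency (the scale is a negative logarithm) and lower numbers for lower potency), the highest of the three numbers shown: compound 1 `CCC(=O)c1ccc2c(c1)C(n1ccccc1=O)=CC(C)(C)O2` gives 6.63 and compound 2 `CC1(C)C=C(n2ccccc2=O)c2cc(C(=O)c3ccco3)ccc2O1` gives 6.49. Compound 4 `Cc1ccc(C)n1-c1ccc2c(c1)C(n1ccccc1=O)=CC(C)(C)O2` differs from compound 3 in one place: 2,5-dimethyl-1H-pyrrol-1-yl in place of 2,2-dicyanoethenyl on an aromatic carbon. Going by the values given here, two measured steps bear on this, both exchanging the group on that same aromatic carbon: a number 0.32 log units higher from compound 1 to compound 3 (beyond the scatter), and a number 0.46 log units higher from compound 2 to compound 3 (beyond the scatter). Each group other than 2,2-dicyanoethenyl tried at this carbon gave a modestly lower number, and 2,5-dimethyl-1H-pyrrol-1-yl has not been tried, so a modest fall is expected rather than a gain. The expected step is therefore a number 0.35 log units lower from compound 3 to compound 4 (beyond the scatter). Compound 4 is estimated to give 6.6 in this assay, with a range from 6.2 to 7.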

Compound 4, logarithm of the reciprocal of the active concentration, log(1/C): 7.27
Compound 4: the middle estimate sits 0.67 log units below what was measured; the measured number lies above the stated range.
By their numbers in this assay, from the lowest: compounds 2 and 1 (each within the scatter of the next); then compound 3; then compound 4.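

The step of a number 0.32 log units higher from compound 3 to compound 4 (beyond the scatter) in this assay shows that 2,2-dicyanoethenyl does not set the upper limit at this aromatic carbon. With a number 0.64 log units higher from compound 1 to compound 4 (beyond the scatter) and a number 0.78 log units higher from compound 2 to compound 4 (beyond the scatter) as well, 2,5-dimethyl-1H-pyrrol-1-yl, which has no carbonyl, stands above both carbonyl-bearing groups at this carbon. No measurement given here explains these steps.

Whether the two methyl groups matter stays open, with no unsubstituted pyrrol-1-yl group among the compounds shown. Also open, on these data alone, is how an amine or a carboxylic acid on this aromatic carbon would compare.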